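Returning a Substituent to the Far Side of the Ring

This account rests on a few compounds, and the source may have more. Where it says the series, first, only, none or still open, it means among the compounds named here.

Within the data shown here, compound 2 `Cc1cccc(N/N=C2\CCC(C)n3c2ncc(C(=O)O)c3=O)c1` has the highest number of the two measured compounds in a functional assay on the whole organism for inhibition, with Rattus norvegicus as the target (a higher number here means that more compound is needed for the effect, a lower number that less compound is needed), giving 72.5 umol/kg; compound 1 `COc1ccc(N/N=C2\CCC(C)n3c2ncc(C(=O)O)c3=O)cc1` gives 7.6 umol/kg, and the only measured step, a 9.5-fold higher number from compound 1 to compound 2 (0.98 log units; beyond the scatter), separates them. Compound 3 `CCc1ccc(N/N=C2\CCC(C)n3c2ncc(C(=O)O)c3=O)cc1` differs from compound 2 by 4-ethylphenyl in place of 3-methylphenyl on an amine nitrogen. That one step bears on the change: 4-ethylphenyl resembles the 4-methoxyphenyl of compound 1 more than the 3-methylphenyl of compound 2 does, so a lower number is expected for compound 3, though ethyl is not methoxy, and a smaller step than a 9.5-fold higher number from compound 1 to compound 2 (0.98 log units; beyond the scatter) seems likely. Compound 3 is estimated at 20 umol/kg, within 6 umol/kg to 70 umol/kg, an expected step of a 3.6-fold lower number from compound 2 to compound 3 (0.56 log units; beyond the scatter).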

Compound 3, dose for 50% inhibition: > 1000 umol/kg
Compound 3: only a limit was reported (the forecaster's own chance of this, stated with the estimate: 5%); middle value at least 50-fold (1.69 log units) from the limit.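

In this assay, compound 3 reaches only a limit of the assay, not a number: the limit of > 1000 umol/kg in this assay, at which 1 of the 3 values shown sits. Ethyl in place of methoxy on an aromatic carbon, a single change, gives an at least 130-fold higher number from compound 1 to compound 3 (2.11 log units; beyond the scatter), so in these compounds the identity of the group counts, not only where it sits. The 4-ethylphenyl group is also no gain over 3-methylphenyl on an amine nitrogen, giving an at least 13-fold higher number from compound 2 to compound 3 (1.13 log units; beyond the scatter).

The compounds shown leave open whether ethoxy or a hydroxyl group on that aromatic carbon would give a number closer to compound 1 or to compound 3.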